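Bromo for amino on a pyrazole-core benzylamine

A few compounds are considered here, and "the series" means these few. Any claim that something is new, unique, unknown or untested is made for them only; others in the source may bear on it.

Compounds measured in an assay for inhibition of Tryptophan 2,3-dioxygenase (Homo sapiens), with stated times of 10 min and 60 min; on this read-out higher numbers stand for weaker inhibition and lower numbers for stronger inhibition:
compound 1, `Oc1ccc(CNc2cc(C(F)(F)F)cc3[nH]ncc23)cc1`, 2550 nM
compound 2, `FC(F)(F)c1cccc(CNc2cc(C(F)(F)F)cc3[nH]ncc23)c1`, 12200 nM
compound 3, `Nc1cccc(CNc2cc(C(F)(F)F)cc3[nH]ncc23)c1`, 2510 nM

Compound 3 gives the lowest of the three numbers in this assay, but the step between it and compound 1 is a 1.0-fold lower number from compound 1 to compound 3 (0.01 log units; within the scatter), so those two cannot be told apart; only compound 2 stands clearly apart, with a 4.9-fold lower number from compound 2 to compound 3 (0.69 log units; beyond the scatter).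

Compound 4, `FC(F)(F)c1cc(NCc2cccc(Br)c2)c2cn[nH]c2c1`, differs from compound 3 by bromo in place of amino on an aromatic carbon. For the measured compounds named here, only one measured step touches this position: the change from compound 2 to compound 3, in which amino entering for trifluoromethyl brought a 4.9-fold lower number from compound 2 to compound 3 (0.69 log units; beyond the scatter). Leaving amino for bromo undoes part of that change, so the number is expected to move back upward, though not necessarily as far as compound 2, since bromo and trifluoromethyl are not the same group and no other step bears on the point. The step from compound 3 to compound 4 is therefore estimated at a 2.4-fold higher number from compound 3 to compound 4 (0.38 log units; beyond the scatter). Compound 4 is expected to give 6000 nM in this assay, within a range of 2000 nM to 18000 nM.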

Compound 4, half-maximal inhibitory concentration: 19100 nM
The estimate for compound 4 lay 3.2-fold (0.50 log units) below the measured number, and the stated range ends below it.
By their numbers in this assay, from the lowest: compounds 3 and 1 (each within the scatter of the next); then compounds 2 and 4 (each within the scatter of the next).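

In this assay bromo proves no better than trifluoromethyl at this position: leaving amino for bromo is a clear loss (a 7.6-fold higher number from compound 3 to compound 4 (0.88 log units; beyond the scatter)), while bromo and trifluoromethyl cannot be told apart (a 1.6-fold higher number from compound 2 to compound 4 (0.19 log units; within the scatter)). The 3-bromophenyl compound also stands clearly apart from the 4-hydroxyphenyl one (a 7.5-fold higher number from compound 1 to compound 4 (0.87 log units; beyond the scatter)). Among the four compounds, the lower numbers therefore belong only to the two that carry amino or hydroxy on the phenyl ring, and the two halogen-bearing groups stay together at the higher end.

Going by these compounds, whether the lower numbers need amino itself remains open, since a hydroxyl, a methylamino or an aminomethyl group at the same place would test this. Nothing at hand explains why amino and bromo differ here.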